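This account rests on a few compounds, and the source may have more. Where it says the series, first, only, none or still open, it means among the compounds named here.

Measured compounds in this study:
compound 1, `N#C/N=C/N=C(\N)N/N=C/c1ccc(Cl)cc1`, with 38000 nM
compound 2, `Nc1ncnc2nc(-c3ccc(Cl)cc3)nn12`, with 100000 nM
compound 3, `Nc1ncnc2nc(-c3ccc(Cl)cc3F)nn12`, with 14100 nM

All three were tested in a functional assay on the whole organism for inhibition, with Scenedesmus acutus as the target, read by spectrophotometry, with a stated time of 48 h; a lower number here means a stronger inhibitor, a higher number a weaker inhibitor. Among them compound 2 stands at the highest number, so it is the weakest inhibitor of the three. Compound 1 gives a lower number, by a gap beyond the scatter, and compound 3 is further away still: a 7.1-fold lower number from compound 2 to compound 3 (0.85 log units; beyond the scatter).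

Compound 4, `CNc1ncnc2nc(-c3ccc(Cl)cc3)nn12`, differs from compound 2 by a single change: methyl in place of hydrogen on a nitrogen on an aromatic ring. Among the measured compounds shown here, no measured step touches this position. For the measured compounds named here, the one step that is known, the fluoro step on the aromatic ring, alters a different place in the molecule and says nothing about a methyl on the ring nitrogen. With no guide from the data, the expectation for this assay is no change beyond the scatter, which would mean no change at the digits printed from compound 2 to compound 4 (within the scatter). Compound 4 is therefore estimated at 100000 nM, with a range from 30000 nM to 300000 nM.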

Compound 4, half-maximal inhibitory concentration: 100000 nM
Estimate against measurement, compound 4: no gap at the digits printed; the range from low to high includes it.
By their numbers in this assay, from the lowest: compound 3; then compound 1; then compounds 2 and 4 (each within the scatter of the next).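

In this assay, among the compounds shown here, the change from amino to methylamino gives no change at the digits printed from compound 2 to compound 4 (within the scatter) and so provides the first reading at this nitrogen on the shared core. A single added methyl here leaves the number where it stood, whereas the fluoro step at an aromatic carbon, a different place in the molecule, gave a 7.1-fold lower number from compound 2 to compound 3 (0.85 log units; beyond the scatter) and did move the number. Nothing available explains why the methyl makes no difference here.

On these data alone, whether a larger group on this nitrogen, such as an ethyl group, a longer chain or an acetyl group, would also leave the number unchanged remains open. So does whether the same methyl would leave the number unchanged on compound 3, which carries the fluoro group.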